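Lengthening the hydroxy chain of compound 2

This account rests on a few compounds, and the source may have more. Where it says the series, first, only, none or still open, it means among the compounds named here.

Measured so far in an ADME assay on the whole organism (Rattus norvegicus) for pharmacokinetics, using cassette dosing, at a dose of 1 mg/kg by the oral route; on this read-out lower numbers stand for lower oral bioavailability and higher numbers for higher oral bioavailability:
- compound 1 `C[C@@H](Cn1c(=O)[nH]/c(=N\c2ccc(Oc3ccc(F)cn3)cc2)n(Cc2ccc(Cl)cc2)c1=O)C(=O)O`: 82.4%
- compound 2 `CC(C)Oc1ccc(Nc2nc(=O)n(CCO)c(=O)n2Cc2ccc(Cl)cc2)cc1Cl`: 48.1%

Of these two, compound 2 stands lower at 48.1%, and the gap up to compound 1 lies beyond the usual scatter. Compound 3 `CC(C)Oc1ccc(Nc2nc(=O)n(CCCO)c(=O)n2Cc2ccc(Cl)cc2)cc1Cl` differs from compound 2 in one place (hydroxymethyl in place of hydroxy on a saturated chain carbon, two bonds along the chain from an aromatic nitrogen): hydroxymethyl in place of hydroxy on a saturated chain carbon, two bonds along the chain from an aromatic nitrogen. In other words, 2-hydroxyethyl becomes 3-hydroxypropyl. Among the compounds with values here, no measured pair shows this change yet. In this assay, no step beyond the scatter is expected. The expected a number 1.1 percentage points lower from compound 2 to compound 3 (within the scatter) stays within that scatter. The estimate for compound 3 is 47%, within a range of 27% to 67%.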

Compound 3, oral bioavailability: 36.2%
The estimate for compound 3 lay 10.8 percentage points above the measured number; the range from low to high includes it.
By their numbers in this assay, from the lowest: compound 3; then compound 2; then compound 1.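

Within the data shown here, measured in this assay the change from 2-hydroxyethyl to 3-hydroxypropyl gives a number 11.9 percentage points lower from compound 2 to compound 3 (beyond the scatter) and is the first step seen at this place on the chain. The change is modest, yet it shows that this read-out can respond to a single added carbon even though the hydrogen-bond donor and acceptor counts and the net charge stay the same. Nothing measured here gives a reason for this step.

One step cannot establish a trend with chain length. On these data alone, how a longer chain such as 4-hydroxybutyl, or an amine or a carboxylic acid in place of the hydroxy, would behave remains open.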